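The source may report more compounds than this note shows. Statements on the series, on what has been measured and on what is new or still open speak of the compounds shown alone.

Measured compounds in an ADME assay on HepG2 2.2.15 cells (Homo sapiens) for cytotoxicity; on this read-out lower numbers stand for higher toxicity in this test and higher numbers for lower toxicity in this test:
- compound 1 `Clc1ccc(C(Oc2ccc3cc(Br)ccc3c2)c2cnc(NCC3CCCCC3)s2)cc1`: "not toxic" (no number reported)
- compound 2 `Cc1ccc(C(=O)Nc2ncc(C(Oc3ccc4cc(Br)ccc4c3)c3ccc(Cl)cc3)s2)cc1`: "not toxic" (no number reported)
- compound 3 `CCc1ccc(S(=O)(=O)Nc2ncc(C(Oc3ccc4cc(Br)ccc4c3)c3ccc(Cl)cc3)s2)cc1`: > 50000 nM

Compound 1 and compound 2 carry no number; for compound 1 this assay reports "not toxic" (no number reported), and for compound 2 likewise "not toxic" (no number reported). Among the measured compounds shown here, compound 3 is the only entry with a value, and that value is a limit of this assay, > 50000 nM; compound 3 therefore sits at the limit of > 50000 nM in this assay, at which 1 of the 3 values shown sits, and the remaining two entries give no number at all, so no step between measured compounds can be stated.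

Compound 4 `O=S(=O)(Nc1ncc(C(Oc2ccc3cc(Br)ccc3c2)c2ccc(Cl)cc2)s1)c1cccc2cccnc12` is not yet measured. It differs from compound 3 by quinolin-8-yl in place of 4-ethylphenyl on a sulfonyl sulfur. Nothing in the three entries distinguishes one member of the shared core from another in this assay, so no step beyond the scatter is expected from compound 3 to compound 4, in either direction; the estimated step that the limit leaves unreadable from compound 3 to compound 4 is meant as none. Compound 4 is expected to come out at 60000 nM, with a range from 25000 nM to 150000 nM, and most probably to be reported only as a limit again, as was the case for compound 3 with > 50000 nM.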

Compound 4, half-maximal cytotoxic concentration: > 50000 nM
Compound 4 ended at the assay's limit (the forecaster's own chance of this, stated with the estimate: 80%); the middle value is on the limit's open side.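

In this assay compound 3 and compound 4 both end at a limit, so no step between them can be read: the limit of > 50000 nM in this assay, at which 2 of the 4 values shown sit.

The compounds shown leave open whether any member of this series reaches a numerical half-maximal cytotoxic concentration in this assay, and how quinolin-8-yl and 4-ethylphenyl on a sulfonyl sulfur compare there.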